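Extending the hydroxyalkyl group on the triazole of compound 2

A few compounds are considered here, and "the series" means these few. Any claim that something is new, unique, unknown or untested is made for them only; others in the source may bear on it.

Measured so far:
Compound 1 `OCc1cn(CCNc2nonc2/C(=N/O)Nc2ccc(F)c(Br)c2)nn1` gives 794 nM in an assay on isolated protein for inhibition of Indoleamine 2,3-dioxygenase 2 (Homo sapiens); on this read-out lower numbers stand for stronger inhibition and higher numbers for weaker inhibition.
Compound 2 `CC(C)(O)c1cn(CCNc2nonc2/C(=N/O)Nc2ccc(F)c(Br)c2)nn1` gives 726 nM in this assay.

Among the compounds with values here, only two compounds have been measured, and the numbers for compound 1 and compound 2 lie within the scatter of each other. Within the data shown here, the one change seen so far, a 1.1-fold lower number from compound 1 to compound 2 (0.04 log units; within the scatter), added carbon at this position without a clear effect. Compound 3 `CCC(C)(O)c1cn(CCNc2nonc2/C(=N/O)Nc2ccc(F)c(Br)c2)nn1` carries methyl in place of hydrogen on a saturated chain carbon, two bonds along the chain from an aromatic carbon and an oxygen on a saturated carbon. Because the earlier step of a 1.1-fold lower number from compound 1 to compound 2 (0.04 log units; within the scatter) stayed within the scatter, a similarly small step is expected here, a 1.1-fold lower number from compound 2 to compound 3 (0.05 log units; within the scatter). Compound 3 is therefore estimated at 650 nM, with a range from 300 nM to 1500 nM.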

Compound 3, half-maximal inhibitory concentration: 958 nM
For compound 3 the middle estimate is 1.5-fold (0.17 log units) below the measured one, within the range that was stated.
By their numbers in this assay, from the lowest: compounds 2, 1 and 3 (each within the scatter of the next).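

In this assay the change from methyl to ethyl gives a 1.3-fold higher number from compound 2 to compound 3 (0.12 log units; within the scatter) and so, like the earlier step, shows no clear effect of added carbon. The full change from hydroxymethyl to 1-hydroxy-1-methylpropyl gives a 1.2-fold higher number from compound 1 to compound 3 (0.08 log units; within the scatter) and so, even taken as a whole, does not separate these three hydroxyalkyl groups on this read-out. No supporting measurement is available to explain these results.

Still open, as far as these compounds go, is how this position responds to a group such as an amine or a carboxylic acid in place of the hydroxyalkyl group. A much longer chain is equally untested by these compounds.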